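A few compounds are considered here, and "the series" means these few. Any claim that something is new, unique, unknown or untested is made for them only; others in the source may bear on it.

Measured so far:
compound 1 `N#C/C(=C\c1ccccc1OS(=O)(=O)c1ccccc1[N+](=O)[O-])C(=O)Nc1nnc(Cc2ccc(F)cc2)s1`: 61%
compound 2 `N#C/C(=C\c1ccccc1OS(=O)(=O)c1ccc(Cl)cc1)C(=O)Nc1nnc(Cc2ccc(F)cc2)s1`: 68%
compound 3 `Cc1ccc(Cc2nnc(NC(=O)/C(C#N)=C/c3ccccc3OS(=O)(=O)c3ccccc3[N+](=O)[O-])s2)cc1`: "not active" (no number reported)

In a functional assay on RS4-11 cells (Homo sapiens) for inhibition, read by CCK-8 assay, with a stated time of 48 h, tested at 20 uM (on this read-out lower numbers stand for less inhibition of growth and higher numbers for more inhibition of growth at the one concentration tested), compound 1 gives 61% and compound 2 gives 68%. The step of a number 7 percentage points higher from compound 1 to compound 2 (within the scatter) corresponds to the change (4-chlorophenyl in place of 2-nitrophenyl on a sulfonyl sulfur). Compound 3 differs from compound 1 in its core by methyl in place of fluoro on an aromatic carbon; in this assay compound 3 is recorded as "not active" (no number reported), without a number behind it. Compound 4 `Cc1ccc(Cc2nnc(NC(=O)/C(C#N)=C/c3ccccc3OS(=O)(=O)c3ccc(Cl)cc3)s2)cc1` remains to be measured. It differs from compound 3 by 4-chlorophenyl in place of 2-nitrophenyl on a sulfonyl sulfur, the same change at the same place as between compound 1 and compound 2. That earlier step a number 7 percentage points higher from compound 1 to compound 2 (within the scatter) stayed within the scatter, so only a small shift from compound 3 is expected here, and compound 3 itself gave no measurable inhibition. Compound 4 is therefore expected to come out low, estimated at 20%. The likely range for compound 4 is estimated from 0% to 45%.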

Compound 4, percent growth inhibition at one concentration: 72%
For compound 4 the middle estimate is 52 percentage points below the measured one; the measured number lies above the stated range.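

In this assay the record gives a number 4 percentage points higher from compound 2 to compound 4 (within the scatter) for methyl in place of fluoro on an aromatic carbon, so with 4-chlorophenyl on the sulfonyl sulfur the two cores read alike. The same sulfonyl change gives a number 7 percentage points higher from compound 1 to compound 2 (within the scatter) on the core of compound 1, whereas on the methyl core compound 3 is "not active" (no number reported) and compound 4 gives 72% in the same assay, so the small step does not carry over, though the step on the methyl core cannot be read as a number. No evidence bearing on a reason for this is at hand.

Open, from the compounds shown here alone, is how a morpholine or a carboxylic acid in place of the aryl group on the sulfonyl sulfur would read on either core. Also open, going by these compounds, is whether a chloro in place of the fluoro or methyl would keep the cores alike.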